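The source may report more compounds than this note shows. Statements on the series, on what has been measured and on what is new or still open speak of the compounds shown alone.

Compound 1 `C=C1CC(Cn2cc(C)c(=O)[nH]c2=O)(c2ccc(-c3ccccc3)cc2)OC1=O` and compound 2 `C=C1CC(Cn2cc(C)c(=O)[nH]c2=O)(c2ccc(F)cc2)OC1=O` were both tested in a functional assay on ACHN cells (Homo sapiens) for inhibition; a higher number here means a weaker inhibitor of growth, a lower number a stronger inhibitor of growth. In this assay compound 1 gives 7590 nM, the highest of the two numbers shown, while compound 2 gives 3550 nM. Among the measured compounds shown here, the one measured step, a 2.1-fold lower number from compound 1 to compound 2 (0.33 log units; beyond the scatter), concerns a different place on the molecule. Compound 3 `C=C1CC(Cn2ccc(=O)[nH]c2=O)(c2ccc(-c3ccccc3)cc2)OC1=O` differs from compound 1 by hydrogen in place of methyl on an aromatic carbon. For the measured compounds named here, no measured step bears on this change, so the step expected is a 1.0-fold higher number from compound 1 to compound 3 (0.00 log units; within the scatter), none beyond the scatter. Compound 3 is therefore estimated to give 7600 nM, with a range from 2500 nM to 23000 nM.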

Compound 3, concentration for 50% growth inhibition: 2290 nM
Beside the measured number, compound 3's estimate is 3.3-fold (0.52 log units) above it, and the stated range ends above it.
By their numbers in this assay, from the lowest: compounds 3 and 2 (each within the scatter of the next); then compound 1.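

Hydrogen in place of methyl on this aromatic carbon brings a 3.3-fold lower number from compound 1 to compound 3 (0.52 log units; beyond the scatter) and so the methyl is not needed for growth inhibition in this assay on the core of compound 1. The loss of a single carbon at this position shifts the number beyond the scatter, which the earlier step, made at a different place, could not show. Nothing available explains this step.

As far as these compounds go, whether hydrogen brings a similar step alongside the fluoro group of compound 2 remains open. So does the response of this position to other groups, such as an ethyl group, a chlorine atom or an amine.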